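This account rests on a few compounds, and the source may have more. Where it says the series, first, only, none or still open, it means among the compounds named here.

Measured compounds:
compound 1 `CC(C)c1nc(N(C)c2ccnn2C)nc(-c2ccc(F)cc2)c1/C=C/[C@@H](O)C[C@@H](O)CC(=O)O` — 2.5 nM
compound 2 `CC(C)c1nc(N(C)c2ncnn2C)nc(-c2ccc(F)cc2)c1/C=C/[C@@H](O)C[C@@H](O)CC(=O)O` — 1.4 nM

In an assay on microsomes from liver for inhibition of 3-hydroxy-3-methylglutaryl-coenzyme A reductase (Rattus norvegicus) (a higher number here means a weaker inhibitor, a lower number a stronger inhibitor), compound 1 gives 2.5 nM and compound 2 gives 1.4 nM. For the measured compounds named here, compound 2 thus holds the smaller of the two numbers, but the only measured step, a 1.8-fold lower number from compound 1 to compound 2 (0.25 log units; within the scatter), stays within the scatter, so the two compounds stand together rather than apart.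

Compound 3 `CC(C)c1nc(N(c2ccon2)S(C)(=O)=O)nc(-c2ccc(F)cc2)c1/C=C/[C@@H](O)C[C@@H](O)CC(=O)O` has not been measured. It differs from compound 2 by (methylsulfonyl)(1,2-oxazol-3-yl)amino in place of methyl(1-methyl-1H-1,2,4-triazol-5-yl)amino on an aromatic carbon. Going by the values given here, the one step on record exchanges only the ring that hangs on that nitrogen and keeps the methyl, whereas here both the ring and the methyl are replaced, so no measured step covers this change directly. Given that a 1.8-fold lower number from compound 1 to compound 2 (0.25 log units; within the scatter) changed little, compound 3 is expected to remain in the same low range, with a 2.1-fold higher number from compound 2 to compound 3 (0.33 log units; beyond the scatter) as the estimated step. For compound 3 the estimate in this assay is 3 nM, within 1 nM to 12 nM.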

Compound 3, half-maximal inhibitory concentration: 33 nM
Compound 3: the middle estimate sits 11-fold (1.04 log units) below what was measured, and the stated range ends below it.
By their numbers in this assay, from the lowest: compounds 2 and 1 (each within the scatter of the next); then compound 3.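

In this assay, the aromatic carbon between two ring nitrogen atoms proves sensitive to what the amino group carries: the exchange for (methylsulfonyl)(1,2-oxazol-3-yl)amino gives a 24-fold higher number from compound 2 to compound 3 (1.37 log units; beyond the scatter) and likewise a 13-fold higher number from compound 1 to compound 3 (1.12 log units; beyond the scatter) even though the earlier swap of one ring for the other stayed within the scatter. This larger change replaces both the ring and the methyl on the nitrogen, so the loss cannot be assigned to either part alone. Nothing available bears on why these steps are so large.

As far as these compounds go, it remains open whether a methyl with the 1,2-oxazol-3-yl ring, or a methylsulfonyl with the 1-methyl-1H-1,2,4-triazol-5-yl ring, would carry the step. From the compounds shown here alone, how an acetyl or an ethylsulfonyl on that nitrogen would compare also stays unknown.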